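The source may hold more compounds than are shown below. What is called first, only, known or untested is meant among the compounds shown, and "the series" means these compounds.

Measured compounds:
Compound 1, `CCC(=CCc1c(O)cc2c(c1O)C(=O)CC(c1ccccc1O)O2)CC`, gives 390 nM in an assay on HEK293 cells for inhibition of Voltage-dependent T-type calcium channel subunit alpha-1H (Homo sapiens), read by patch clamp, with a stated time of 10 min; a higher number here means a weaker inhibitor, a lower number a stronger inhibitor.
Compound 2, `CCC(=CCc1c(O)cc2c(c1O)C(=O)CC(c1ccc(O)cc1)O2)CC`, gives 260 nM in this assay.

Compound 2 shares its core with compound 1, the two differing only in where the hydroxyl sits on the phenyl ring carried on a saturated ring carbon. On the numbers shown, compound 2 sits alongside compound 1 rather than apart from it: a 1.5-fold lower number from compound 1 to compound 2 (0.18 log units; within the scatter), so nothing separates the two beyond the ordinary spread of repeat measurements.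

Compound 3, `CC(C)CCc1c(O)cc2c(c1O)C(=O)CC(c1ccc(O)cc1)O2`, has not yet been measured. It keeps the 4-hydroxyphenyl of compound 2 and changes the side chain instead: a group of 4 heavy atoms (4 carbon; no ring) in place of a group of 6 heavy atoms (6 carbon; no ring), on a saturated chain carbon bound to an aromatic carbon. Within the data shown here, no measured step touches this chain; the one step known, from compound 1 to compound 2, changes a different part of the molecule and was itself within the scatter. There is therefore no basis for expecting a shift in this assay in either direction beyond the scatter, and the expected step is a 1.3-fold higher number from compound 2 to compound 3 (0.13 log units; within the scatter). For compound 3 the estimate in this assay is 350 nM, within a range of 130 nM to 1000 nM.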

Compound 3, half-maximal inhibitory concentration: 480 nM
Compound 3: the middle estimate sits 1.4-fold (0.14 log units) below what was measured; measured number inside the range.
By their numbers in this assay, from the lowest: compounds 2, 1 and 3 (each within the scatter of the next).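

The side chain on a saturated chain carbon bound to an aromatic carbon now has its first reading: replacing the group of 6 heavy atoms, which carries a double bond, with isobutyl gives a 1.8-fold higher number from compound 2 to compound 3 (0.27 log units; within the scatter) in this assay. This position can therefore take this change of size and the loss of that double bond without a shift that can be told apart from repeat measurements, although one step cannot show how far that tolerance extends. Nothing available explains the result or links it to any measured property of these groups.

Still open, going by these compounds, is whether a longer chain, an amine or a carboxylic acid at this position would move the number beyond the scatter. The compounds shown also leave open whether isobutyl would behave in the same way alongside the 2-hydroxyphenyl group of compound 1.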